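This account rests on a few compounds, and the source may have more. Where it says the series, first, only, none or still open, it means among the compounds named here.

In an assay on CHO cells for antagonist activity at transient receptor potential cation channel subfamily V member 1 (Homo sapiens), read by FLIPR (a higher number here means a weaker inhibitor, a lower number a stronger inhibitor), the measured compounds stand as follows:
compound 1, `CC(C(=O)NCc1ccc(C(F)(F)F)cc1N1CCN(C2CCCCC2)CC1)c1ccc(NS(C)(=O)=O)c(F)c1`, gives 13.8 nM;
compound 2, `CC(C)CCOc1cc(C(F)(F)F)ccc1CNC(=O)C(C)c1ccc(NS(C)(=O)=O)c(F)c1`, gives 0.5 nM;
compound 3, `CC(C(=O)NCc1ccc(C(F)(F)F)cc1SC1CCCCC1)c1ccc(NS(C)(=O)=O)c(F)c1`, gives 0.5 nM.

Compound 3 is level with compound 2 at the digits shown, the two together the lowest numbers of the three; compound 1 sits far above both, with a 28-fold lower number from compound 1 to compound 3 (1.44 log units; beyond the scatter) and a 28-fold lower number from compound 1 to compound 2 (1.44 log units; beyond the scatter), while no change at the digits printed from compound 2 to compound 3 (within the scatter).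

Compound 4, `CC(C(=O)NCc1ccc(C(F)(F)F)cc1[N+](=O)[O-])c1ccc(NS(C)(=O)=O)c(F)c1`, differs from compound 3 by nitro in place of cyclohexylsulfanyl on an aromatic carbon. Going by the values given here, no measured step covers this exchange. The steps from compound 1 show that the group on this aromatic carbon can move the number by a large margin, and the two low values belong to compounds 2 and 3 carrying isopentyloxy or cyclohexylsulfanyl there. For compound 4 a weakening is therefore expected, with a 20-fold higher number from compound 3 to compound 4 (1.30 log units; beyond the scatter) as the estimated step. Compound 4 is estimated at 10 nM, within 2 nM to 60 nM.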

Compound 4, inhibition constant: "not active" (no number reported)
Compound 4: no number reported, so the estimate cannot be set against anything.
By their numbers in this assay, from the lowest: compounds 2 and 3 (each within the scatter of the next); then compound 1.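

Going by these compounds alone, compound 4 is reported as "not active" in this assay without a number, so no step from compound 3 can be read. How nitro compares numerically with cyclohexylsulfanyl stays open, and nothing shown here bears on an explanation.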